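Methyl in Place of Fluoro on an Aromatic Carbon

The compounds below may be only part of what the source reports. "The series", "measured", "known", "first", "only" and "open" are said of these compounds alone.

Among the measured compounds shown here, in a functional assay on HepG2 cells (Homo sapiens) for antiproliferative activity, read by MTT assay, with a stated time of 48 h (a lower number here means a stronger inhibitor, a higher number a weaker inhibitor), compound 1 (`COc1ccc(-c2c(Nc3ccc(F)cc3)c3ccccc3oc2=O)cc1`) gives 35500 nM, the higher of the two numbers measured so far. For the measured compounds named here, the only other measured compound, compound 2 (`COc1ccc(-c2c(Nc3ccc(C)c(O)c3)c3ccccc3oc2=O)cc1`), gives 10200 nM. Compound 3 (`COc1ccc(-c2c(Nc3ccc(C)cc3)c3ccccc3oc2=O)cc1`) keeps the core of compound 1 and changes it in one place: methyl in place of fluoro on an aromatic carbon. The exchange lies para to a large group and turns 4-fluorophenyl into 4-methylphenyl.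

Going by the values given here, one measured step bears on this change: a 3.5-fold lower number from compound 1 to compound 2 (0.54 log units; beyond the scatter). That step also removes the 4-fluorophenyl group, but the 3-hydroxy-4-methylphenyl group that replaces it differs from the 4-methylphenyl group of compound 3. Among the compounds with values here, no measured step isolates the exchange of fluoro for methyl, so this evidence is indirect. A smaller move in the same direction is expected in this assay, possibly no larger than the scatter. The expected change is a 1.6-fold lower number from compound 1 to compound 3 (0.21 log units; within the scatter). Compound 3 is estimated at 22000 nM, with an expected range of 10000 nM to 48000 nM.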

Compound 3, half-maximal inhibitory concentration: 59400 nM
Compound 3: the middle estimate sits 2.7-fold (0.43 log units) below what was measured, outside the stated range (above it).
By their numbers in this assay, from the lowest: compound 2; then compounds 1 and 3 (each within the scatter of the next).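

Among the compounds shown here, compound 3 gives the first reading that isolates the exchange of fluoro for methyl on this aromatic carbon, para to a large group, and the step (a 1.7-fold higher number from compound 1 to compound 3 (0.22 log units; within the scatter)) leaves the two groups unresolved in this assay. The other new comparison changes only the hydroxy group and is beyond the scatter (a 5.8-fold higher number from compound 2 to compound 3 (0.77 log units; beyond the scatter)), so among these three compounds the lower number of compound 2 goes with the presence of that hydroxy group and not with the methyl group it shares with compound 3. The compounds shown hold no measurement that accounts for either step.

On these data alone, whether the hydroxy group would go with a similar step alongside fluoro in place of methyl remains open, since the hydroxy group appears here only in compound 2, and a single pair cannot show whether the step depends on the group beside which it sits. As far as these compounds go, it also remains open how an amine, a carboxylic acid, a methoxy group or a longer chain such as propyl would read on the aromatic carbon that carries fluoro in compound 1 and methyl in compound 3.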